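The source may report more compounds than this note shows. Statements on the series, on what has been measured and on what is new or still open speak of the compounds shown alone.

Measured so far in an ADME assay on HEK293 cells (Homo sapiens) for cytotoxicity, read by luminescence, with a stated time of 72 h (a lower number here means that less compound is needed, a higher number that more compound is needed for the effect), each entry a limit and not a number:
compound 1 `CCOC(=O)c1c(-c2cccc(Oc3ccccc3)c2)[nH]c2cc(OC)c(F)cc2c1=O` (> 22000 nM)
compound 2 `CCOC(=O)c1c(-c2cccc(Cl)c2)[nH]c2cc(OC)c(F)cc2c1=O` (> 22000 nM)
compound 3 `CCOC(=O)c1c(-c2cccc(-c3c(C)cccc3C)c2)[nH]c2cc(OC)c(F)cc2c1=O` (> 22000 nM)

Compound 1 has no number, only a limit (> 22000 nM). The whole set sits there (the limit of > 22000 nM in this assay, at which 3 of the 3 values shown sit).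

Compound 4 `COc1cc2[nH]c(-c3cccc(Oc4ccccc4)c3)c(C(=O)NCCCN3CCCC3)c(=O)c2cc1F` differs from compound 1 in one place ((3-(pyrrolidin-1-yl)propyl)amino in place of ethoxy on a carbonyl carbon), with (3-(pyrrolidin-1-yl)propyl)amino in place of ethoxy on a carbonyl carbon. The measured steps give no size to carry over: a step that the two limits leave unreadable from compound 1 to compound 2 and a step that the two limits leave unreadable from compound 1 to compound 3 and a step that the two limits leave unreadable from compound 2 to compound 3. All three act on an aromatic carbon, not on the carbonyl carbon.

Only a step toward a lower number could be read in this assay, so that direction is expected, with its size uncertain and a further limit quite possible. The expected step is an at least 1.4-fold lower number from compound 1 to compound 4 (0.16 log units; that floor lies within the scatter). For compound 4 the estimated value is 15000 nM, with an expected range from 5000 nM to 30000 nM.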

Compound 4, half-maximal effective concentration: > 22000 nM
Compound 4: only a limit was reported; the forecaster's own chance of this, stated with the estimate: 50%; middle value at least 1.4-fold (0.16 log units) away from the limit.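

No new step can be read from compound 1 to compound 4 in this assay, since both values are limits: the limit of > 22000 nM in this assay, at which 4 of the 4 values shown sit.

The compounds shown leave open whether (3-(pyrrolidin-1-yl)propyl)amino in place of ethoxy changes the number at all.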